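Swapping Methyl for Methoxy on the Benzyl Ring

The source may hold more compounds than are shown below. What is called first, only, known or untested is meant among the compounds shown, and "the series" means these compounds.

Compound 1 `COc1cccc(OC)c1OCCNCCOc1ccccc1OCc1cccc(Cl)c1` gives 58900 nM in a functional assay on PC-3 cells (Homo sapiens) for cytotoxicity, read by sulforhodamine B assay; on this read-out lower numbers stand for higher toxicity in this test and higher numbers for lower toxicity in this test.
Compound 2 `COc1cccc(OC)c1OCCNCCOc1ccccc1OCc1ccc(Cl)cc1` gives 52500 nM in this assay.
Compound 3 `COc1cccc(OC)c1OCCNCCOc1ccccc1OCc1cccc(C)c1` gives 87100 nM in this assay.

Compound 3 holds the highest of the three numbers in this assay, yet its steps from the others, a 1.5-fold higher number from compound 1 to compound 3 (0.17 log units; within the scatter) and a 1.7-fold higher number from compound 2 to compound 3 (0.22 log units; within the scatter), both stay within the scatter. Compound 4 `COc1cccc(COc2ccccc2OCCNCCOc2c(OC)cccc2OC)c1` differs from compound 3 by methoxy in place of methyl on an aromatic carbon. Among the compounds with values here, no measured step makes this exact change; the nearest comparisons are a 1.1-fold lower number from compound 1 to compound 2 (0.05 log units; within the scatter), where 4-chlorophenyl replaces 3-chlorophenyl, and a 1.5-fold higher number from compound 1 to compound 3 (0.17 log units; within the scatter), where methyl replaces chloro, and each stayed within the scatter. Small changes on this ring have so far left the number where it was, so the expected step is a 1.1-fold lower number from compound 3 to compound 4 (0.04 log units; within the scatter), nothing beyond the scatter. Compound 4 is therefore estimated at 80000 nM, within a range of 40000 nM to 160000 nM.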

Compound 4, concentration lethal to 50% of the cells: 61700 nM
Estimate against measurement, compound 4: 1.3-fold (0.11 log units) above; the measured number falls inside the stated range.
By their numbers in this assay, from the lowest: compounds 2, 1, 4 and 3 (each within the scatter of the next).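

Methoxy, which adds a hydrogen-bond acceptor that methyl lacks, changes little at this position: a 1.4-fold lower number from compound 3 to compound 4 (0.15 log units; within the scatter) in this assay stays within the scatter. Against the chlorinated compounds, a 1.0-fold higher number from compound 1 to compound 4 (0.02 log units; within the scatter) and a 1.2-fold higher number from compound 2 to compound 4 (0.07 log units; within the scatter) also stay within it, so chloro, methyl and methoxy cannot be told apart here. No supporting measurement offers an explanation for this flat result. From the compounds shown here alone, whether an amine or a carboxylic acid on this ring would move the number beyond the scatter remains open.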